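Swapping methoxy for fluoro on an alkyne-linked phenyl ring

The source may report more compounds than this note shows. Statements on the series, on what has been measured and on what is new or still open speak of the compounds shown alone.

Compound 1 `COC(=O)c1sc2cc(C#Cc3ccccc3OC)cnc2c1N` carries a 2-methoxyphenyl group on a triple-bonded carbon. In a functional assay on NCI-H460 cells (Homo sapiens) for inhibition, read by sulforhodamine B assay, with a stated time of 48 h (on this read-out lower numbers stand for stronger inhibition of growth and higher numbers for weaker inhibition of growth), compound 1 gives > 47300 nM, which is a limit of the assay rather than a number. Compound 2 `COC(=O)c1sc2cc(C#Cc3cccnc3)cnc2c1N` differs from compound 1 by pyridin-3-yl in place of 2-methoxyphenyl on a triple-bonded carbon. In this assay compound 2 gives > 150000 nM, again a limit. The step that the two limits leave unreadable from compound 1 to compound 2 therefore has no readable size. Compound 3 `COC(=O)c1sc2cc(C#Cc3ccccc3F)cnc2c1N` is the compound still to be measured; it differs from compound 1 by fluoro in place of methoxy on an aromatic carbon. Within the data shown here, the only step available, from compound 1 to compound 2, ends at the limit of > 150000 nM in this assay, at which 1 of the 2 values shown sits, and starts at the limit of > 47300 nM in this assay, at which 1 of the 2 values shown sits, so it gives no size that could be carried over to the new change. With compound 1 standing at a limit, no direction can be read either, and compound 3 is expected to stay in the same weak region, with the step that the limit leaves unreadable from compound 1 to compound 3 expected to fall within the scatter. Compound 3 is therefore estimated at 60000 nM, between 20000 nM and 200000 nM, and the assay may well report only a limit again.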

Compound 3, concentration for 50% growth inhibition: > 150000 nM
Compound 3: only a limit was reported; the forecaster's own chance of this, stated with the estimate: 70%; middle value at least 2.5-fold (0.39 log units) away from the limit.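

In this assay compound 3 gives > 150000 nM, which is a limit of the assay rather than a number. Among these compounds, compound 1, compound 2 and compound 3 all stand at limits, so no step between them can be read. The compounds shown leave open how strongly each one inhibits growth, and whether 2-methoxyphenyl, 2-fluorophenyl or pyridin-3-yl makes any difference.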